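The compounds below may be only part of what the source reports. "The series", "measured", "known", "first", "only" and "open" are said of these compounds alone.

In a physicochemical assay for solubility, using the shake flask method, measured as kinetic solubility, with a stated time of 20 h, at pH 2 (on this read-out higher numbers stand for higher solubility and lower numbers for lower solubility), compound 3 `FC(F)(F)c1ccc(Nc2cc3[nH]c(C4CCOC4)nc3cn2)nc1` gives 200000 nM, which is within the scatter of compound 2 `FC1(F)CCC(c2nc3cnc(Nc4ccc(C(F)(F)F)cn4)cc3[nH]2)C1` at 185000 nM, and together they top the numbers. Compound 1 `FC(F)(F)c1ccc(Nc2cc3[nH]c(-c4cccc(C(F)(F)F)c4)nc3cn2)nc1` reports only a limit, < 5000 nM. Compound 4 `FC(F)(F)c1ccc(Nc2cc3[nH]c(CC4CC4)nc3cn2)nc1` carries cyclopropylmethyl in place of oxolan-3-yl on an aromatic carbon. Two large steps came from replacing 3-(trifluoromethyl)phenyl, an at least 37-fold higher number from compound 1 to compound 2 (1.56 log units; beyond the scatter) and an at least 40-fold higher number from compound 1 to compound 3 (1.60 log units; beyond the scatter). Exchanging one non-aromatic ring group for another gave only a 1.1-fold higher number from compound 2 to compound 3 (0.03 log units; within the scatter), and that step is the closest guide here. The expected step is a 1.7-fold lower number from compound 3 to compound 4 (0.22 log units; within the scatter), so little real change is anticipated. For compound 4 the estimated value is 120000 nM, with an expected range from 30000 nM to 230000 nM.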

Compound 4, solubility: 186000 nM
Beside the measured number, compound 4's estimate is 1.6-fold (0.19 log units) below it, within the range that was stated.
By their numbers in this assay, from the lowest: compounds 2, 4 and 3 (each within the scatter of the next). At a limit, below all of these: compound 1.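

In this assay, a carbon-only group, cyclopropylmethyl, on this aromatic carbon between two ring nitrogen atoms matches the earlier non-aromatic groups, with a 1.1-fold lower number from compound 3 to compound 4 (0.03 log units; within the scatter) and a 1.0-fold higher number from compound 2 to compound 4 (0.00 log units; within the scatter), so the oxygen of oxolan-3-yl and the fluorines of 3,3-difluorocyclopentyl are not needed for these numbers. The large step away from 3-(trifluoromethyl)phenyl also recurs, with an at least 37-fold higher number from compound 1 to compound 4 (1.57 log units; beyond the scatter). Compound 1 gives a limit, not a number: the limit of < 5000 nM in this assay, at which 1 of the 4 values shown sits.

From the compounds shown here alone, whether an unsubstituted phenyl would behave like compound 1 or like compound 4 stays open, which leaves the aromatic ring and its trifluoromethyl group unseparated. Going by these compounds, how an amine or a carboxylic acid at this position would read also stays open.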